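A few compounds are considered here, and "the series" means these few. Any claim that something is new, unique, unknown or untested is made for them only; others in the source may bear on it.

Measured compounds:
compound 1 `CCCCOc1cc(C(=O)NC)nn1-c1ccccc1` with 65%
compound 2 `CCCCOc1cc(C(=O)N(C)C)nn1-c1ccccc1` with 18.7%
compound 3 `C=CCNC(=O)c1cc(OCCCC)n(-c2ccccc2)n1` with 4.4%

In a functional assay on the whole organism (strain Wistar) for inhibition, with Rattus norvegicus as the target, read by paw edema, with stated times of 30 min and 3 h, at a dose of 100 mg/kg by the oral route (a higher number here means more inhibition at the dose given (going by the name of the read-out), a lower number less inhibition), compound 3 stands lowest of the three, a number 14.3 percentage points lower from compound 2 to compound 3 (beyond the scatter) and a number 60.6 percentage points lower from compound 1 to compound 3 (beyond the scatter).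

Compound 4 `CCCCOc1cc(C(=O)NCCC)nn1-c1ccccc1` has not yet been measured. It differs from compound 3 in one place: ethyl in place of vinyl on a saturated chain carbon bound to an amide-type nitrogen The saturated propyl chain stays on the amide-type nitrogen, so compound 4 keeps the larger substituent that compound 3 carries there, and only the double bond within it is lost.

Among the compounds with values here, no measured pair shows this same change. The nearest guides are the steps that alter the group on the amide-type nitrogen: a number 46.3 percentage points lower from compound 1 to compound 2 (beyond the scatter) and a number 60.6 percentage points lower from compound 1 to compound 3 (beyond the scatter), both large drops away from the small methyl of compound 1. Since compound 4 keeps a three-carbon chain on that nitrogen, a low value is expected, and the step from compound 3 is expected to be small, a number 10.6 percentage points higher from compound 3 to compound 4 (beyond the scatter). Compound 4 is therefore estimated at 15%, with a range from 0% to 40%.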

Compound 4, a percentage reported as inhibition, in the whole organism at one dose (the size of the read-out at that dose, not a potency): 51.2%
Compound 4: the middle estimate sits 36.2 percentage points below what was measured; measured number outside the range, above it.
By their numbers in this assay, from the lowest: compound 3; then compound 2; then compound 4; then compound 1.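

With the same chain length kept on the amide-type nitrogen, losing only the double bond proves a large change in this assay (a number 46.8 percentage points higher from compound 3 to compound 4 (beyond the scatter)). A three-carbon chain there is therefore compatible with a high number, since the full step from the amide hydrogen to the propyl chain is only modest (a number 13.8 percentage points lower from compound 1 to compound 4 (beyond the scatter)). The propylamino group also gives a much higher number than the dimethylamino group on the carbonyl carbon (a number 32.5 percentage points higher from compound 2 to compound 4 (beyond the scatter)), although compound 3 shows that keeping the amide hydrogen does not by itself give a high number.

Going by these compounds, whether a longer chain, or one ending in an amine, would keep the number high on this nitrogen remains open. Nothing available explains why the double bond matters so much here.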